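The source may hold more compounds than are shown below. What is called first, only, known or untested is meant among the compounds shown, and "the series" means these compounds.

Going by the values given here, compound 1 `CC(C)c1ccc(NC2=NCCC3(CCCCC3)S2)cc1` is one of three compounds measured in a physicochemical assay for lipophilicity, measured as octanol-water partition, at pH 7.4 (on this read-out higher numbers stand for higher lipophilicity and lower numbers for lower lipophilicity), and there compound 1 gives 1.57, the lowest of the three. Compound 3 `Fc1ccc(NC2=NCCC3(CCCCC3)S2)cc1Cl` gives 2.03, and compound 2 `Brc1ccc(NC2=NCCC3(CCCCC3)S2)cc1` gives 2.53. Among the compounds with values here, the one measured step that starts from compound 1 is a number 0.96 log units higher from compound 1 to compound 2 (beyond the scatter). Compound 4 `c1ccc(NC2=NCCC3(CCCCC3)S2)cc1` differs from compound 1 by hydrogen in place of isopropyl on an aromatic carbon. Within the data shown here, no measured step removes a group outright, so the step from compound 1 to compound 2 bears on this change only loosely, as the sole sign of how far a change at that aromatic carbon can move this assay. A drop beyond the scatter is expected, a number 0.67 log units lower from compound 1 to compound 4 (beyond the scatter), so compound 4 is estimated at 0.9, within 0.2 to 1.7.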

Compound 4, distribution coefficient: 1.02
Compound 4: middle estimate off by 0.12 log units, on the low side; measured number inside the range.
By their numbers in this assay, from the lowest: compound 4; then compound 1; then compound 3; then compound 2.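

Taking the group away altogether gives this aromatic carbon its plain hydrogen reference in this assay: isopropyl gives way to hydrogen with a number 0.55 log units lower from compound 1 to compound 4 (beyond the scatter), and bromo gives way to hydrogen with a number 1.51 log units lower from compound 2 to compound 4 (beyond the scatter). Both replacements by hydrogen lower the number, and the one from bromo is the larger, so compound 4 now lies under both groups at this place. No information at hand accounts for the size of either step. Still open, from the compounds shown here alone, is where a carboxylic acid, an amine or a longer chain on this carbon would fall relative to hydrogen, and whether the order seen here would hold on a different core.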